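Chloro in place of hydrogen on two cores

The source may report more compounds than this note shows. Statements on the series, on what has been measured and on what is new or still open speak of the compounds shown alone.

Compound 1 `Cc1[nH]c2ccccc2c1C(c1ccccc1)c1cc2ccccc2o1` and compound 2 `Cc1[nH]c2ccccc2c1C(c1ccccc1)c1cc2cc(Cl)ccc2o1` share one core; compound 3 `CC(C)(C)c1cc(C(C)(C)C)c2oc(C(c3ccccc3)c3c[nH]c4ccccc34)cc2c1` and compound 4 `CC(C)(C)c1cc(C(C)(C)C)c2oc(C(c3ccc(Cl)cc3)c3c[nH]c4ccccc34)cc2c1` share another, and the difference between the two cores is not broken down here. In a functional assay on SiHa cells (Homo sapiens) for cytotoxicity (on this read-out higher numbers stand for weaker inhibition and lower numbers for stronger inhibition), compound 1 gives 56500 nM, compound 2 gives 47500 nM and compound 3 gives 61600 nM, all three within the scatter of one another. The change from compound 1 to compound 2 is chloro in place of hydrogen on an aromatic carbon, which made a 1.2-fold lower number from compound 1 to compound 2 (0.08 log units; within the scatter). The change from compound 3 to compound 4 is chloro in place of hydrogen on an aromatic carbon, read one bond further out as phenyl to 4-chlorophenyl. It is the same kind of change, but the place differs: in compound 2 the chloro sits on a ring that is part of a fused or bridged system of two rings, meta to a fused ring and para to a fused ring, whereas in compound 4 it sits para to a large group. Going by the values given here, the step expected in this assay is a 1.2-fold lower number from compound 3 to compound 4 (0.09 log units; within the scatter), because a 1.2-fold lower number from compound 1 to compound 2 (0.08 log units; within the scatter) stayed within the scatter and no other precedent exists. Compound 4 is therefore estimated at 50000 nM, between 25000 nM and 100000 nM.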

Compound 4, half-maximal inhibitory concentration: 49800 nM
The estimate for compound 4 lay 1.0-fold (0.00 log units) above the measured number; the measured number falls inside the stated range.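

In this assay, chloro in place of hydrogen on an aromatic carbon gives a 1.2-fold lower number from compound 3 to compound 4 (0.09 log units; within the scatter), and the step agrees with the one on the other core: the same change on two cores in this assay, a 1.2-fold lower number (0.08 log units; within the scatter) from compound 1 to compound 2 and a 1.2-fold lower number (0.09 log units; within the scatter) from compound 3 to compound 4, 1.0-fold (0.02 log units) apart, within the scatter of two such steps

Across these two cores, the change therefore behaves alike, with neither step leaving the scatter. This does not show that the change carries a real effect of a set size from core to core, since the agreement is between two steps too small to read, and it cannot separate the core from the place, since the chloro sits at a different place in compound 2 and compound 4.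

The compounds shown leave open whether a different group on the same aromatic carbon of compound 3, such as an amine, a methoxy group or a carboxylic acid, would move the number in this assay beyond the scatter. They also leave open whether chloro at one matching place on both cores would give the same step.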